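Swapping Hydroxy for Anilino on a Flat Series

A few compounds are considered here, and "the series" means these few. Any claim that something is new, unique, unknown or untested is made for them only; others in the source may bear on it.

Of the compounds shown here, three give the same reading, so the numbers so far offer little contrast. In an ADME assay on Raji cells (Homo sapiens) for cytotoxicity, read by CellTiter-Glo, with a stated time of 72 h (on this read-out lower numbers stand for an effect already at smaller amounts and higher numbers for an effect only at larger amounts of compound), compound 3 `C/C1=C/C2=C[C@H](C)C[C@@]23O[C@]2(CC(C)(C)[C@@H](O)[C@@H]2C1=O)[C@@H](C)C3=O` gives 26000 nM. Compound 1 `C/C1=C/[C@]23O[C@H]2[C@H](C)C=C3C(=O)[C@@](C)(O)C(=O)CC(C)(C)/C=C/C1=O` gives 26000 nM, and compound 2 `COc1ccc(/C2=C\C(=O)/C(C)=C\C3=C[C@H](C)C[C@@]34OC(=C(C)C4=O)CC2(C)C)cc1` gives 26000 nM, which leaves compound 3 level with both.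

The next structure, compound 4 `C/C1=C/C2=C[C@H](C)C[C@@]23O[C@]2(CC(C)(C)[C@@H](Nc4ccccc4)[C@@H]2C1=O)[C@@H](C)C3=O`, is compound 3 with anilino in place of hydroxy on a saturated ring carbon. Among the compounds with values here, no two measured compounds differ in one place only, so the data hold no direct guide to this swap. The nearest hint is compound 2, which carries an aromatic ring of its own and still gives 26000 nM, and that argues against a large shift. In this assay a step no larger than the scatter is therefore expected, with a slight lean toward lower numbers. The expected step is a 1.6-fold lower number from compound 3 to compound 4 (0.21 log units; within the scatter). For compound 4 the estimate is 16000 nM, with an expected range of 5000 nM to 32000 nM.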

Compound 4, half-maximal effective concentration: 26000 nM
Beside the measured number, compound 4's estimate is 1.6-fold (0.21 log units) below it; the range from low to high includes it.
By their numbers in this assay, from the lowest: compounds 1, 2, 3 and 4 (each within the scatter of the next).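

Within the data shown here, this is the first one-place comparison. On this saturated ring carbon of a five-membered non-aromatic ring, next to the ring atom that bears two methyl groups, replacing hydroxy with anilino gives, in this assay, no change at the digits printed from compound 3 to compound 4 (within the scatter). At this position, then, a group of 7 heavy atoms carrying a six-membered aromatic ring reads the same as a group of 1 heavy atom, and no information here explains why.

A single swap cannot show whether every group at this carbon would read alike, and a carboxylic acid, a simple alkyl amine or a longer chain might not. As far as these compounds go, whether a one-place change elsewhere on the shared core would move the number also remains open.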